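Cyano in place of methyl on a pyrrole-linked phenyl ring

The source may hold more compounds than are shown below. What is called first, only, known or untested is meant among the compounds shown, and "the series" means these compounds.

Of the compounds shown here, three sharing one core have been measured in a functional assay on the whole organism (strain Wistar) for inhibition, with Rattus norvegicus as the target, read by paw edema, with stated times of 30 min and 3 h, at a dose of 200 mg/kg by the oral route; on this read-out higher numbers stand for more inhibition at the one dose given (going by the name of the read-out) and lower numbers for less inhibition. Compound 1 `CC(=O)Oc1ccc(-n2c(-c3ccccc3)cc3c2CCCC3)cc1C(=O)O` gives 50%. Compound 2 `O=C(O)c1cc(-n2c(-c3ccccc3)cc3c2CCCC3)cc(Cl)c1O` gives 0%. Compound 3 `Cc1ccc(-c2cc3c(n2-c2ccc(O)c(C(=O)O)c2)CCCC3)cc1` gives 30%, which stands second highest of the three numbers: compound 1 is higher by a gap beyond the scatter, and compound 2 lies lower by a gap also beyond the scatter. Compound 4 `N#Cc1ccc(-c2cc3c(n2-c2ccc(O)c(C(=O)O)c2)CCCC3)cc1` remains to be measured in this assay. It differs from compound 3 as follows: cyano in place of methyl on an aromatic carbon. Within the data shown here, no measured pair shows what such a change does here, so the estimate rests on compound 3 alone. For compound 4 the expected outcome is 30%, with a range from 10% to 55%. The expected step of no change at the digits printed from compound 3 to compound 4 (within the scatter) is therefore none beyond the scatter.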

Compound 4, a percentage reported as inhibition, in the whole organism at one dose (the size of the read-out at that dose, not a potency): 0%
Estimate against measurement, compound 4: 30 percentage points above; measured number below the stated range.
By their numbers in this assay, from the lowest: compounds 2 and 4 (each within the scatter of the next); then compound 3; then compound 1.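

In this assay the exchange of 4-methylphenyl for 4-cyanophenyl gives a number 30 percentage points lower from compound 3 to compound 4 (beyond the scatter) and so shows that inhibition depends on the group carried at this place, para to a large group. Among these compounds, this is the first pair differing in one place, which ties the drop to that single exchange. Nothing available gives a reason for the drop. Going by these compounds, what an amine, a methoxy group or a chlorine at this place would give remains open, as does whether the acetyl ester of compound 1 would change the outcome for compound 4.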